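Ester side-chain variation on the dihydropyridine acid series

The compounds below may be only part of what the source reports. "The series", "measured", "known", "first", "only" and "open" are said of these compounds alone.

Measured compounds:
- compound 1 `CC1=NC(C)=C(C(=O)O)C(c2cccc(C(=O)O)c2)/C1=C(\O)OC/C=C/c1ccccc1`: 37000 nM
- compound 2 `CC1=NC(C)=C(C(=O)O)C(c2cccc(Cl)c2)/C1=C(\O)OC/C=C/c1ccc(Cl)cc1`: 1500 nM
- compound 3 `CC1=NC(C)=C(C(=O)O)C(c2cccc(Cl)c2)/C1=C(\O)OC/C=C/c1ccncc1`: 6200 nM

All three numbers come from a functional assay on IMR-32 cells for inhibition of Voltage-dependent N-type calcium channel subunit alpha-1B (Homo sapiens), read by calcium flux; on this read-out higher numbers stand for weaker inhibition and lower numbers for stronger inhibition. Compound 3 stands second highest of the three: its nearest neighbour is compound 2 with 1500 nM, and the furthest is compound 1 with 37000 nM. Among the measured compounds shown here, compound 1 differs from compound 2 in more than one place, so its two values are only set side by side here and no single step is drawn from them.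

For the measured compounds named here, the one measured single-point step is a 4.1-fold higher number from compound 2 to compound 3 (0.62 log units; beyond the scatter).

Compound 4 `CC1=NC(C)=C(C(=O)O)C(c2cccc(Cl)c2)/C1=C(\O)OCc1ccc2ccccc2c1` is not yet measured. Relative to compound 3 the change is naphthalen-2-yl in place of 2-(pyridin-4-yl)ethenyl on a saturated chain carbon bound to an oxygen on an unsaturated carbon. Going by the values given here, no measured step matches this change, which replaces the whole ethenyl-linked ring rather than only the ring. Among the compounds with values here, the only step that bears on it is the one from compound 2 to compound 3, where an all-carbon ring in the ester side chain went with the lower number. Compound 4 again carries an all-carbon aromatic system in that position, so the number in this assay is expected to fall back toward that of compound 2, a modest step downward, a 2.5-fold lower number from compound 3 to compound 4 (0.39 log units; beyond the scatter), with wide uncertainty because the ethenyl chain is also gone. For compound 4 the estimate in this assay is 2500 nM, expected between 700 nM and 9000 nM.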

Compound 4, half-maximal inhibitory concentration: 1000 nM
Compound 4: middle estimate off by 2.5-fold (0.40 log units), on the high side, and the stated range covers the measured number.
By their numbers in this assay, from the lowest: compounds 4 and 2 (each within the scatter of the next); then compound 3; then compound 1.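

Notes on the ester side chain: in this assay the ethenyl link is not needed for a low number, since naphthalen-2-yl on the saturated chain carbon bound to an oxygen on an unsaturated carbon gives a 6.2-fold lower number from compound 3 to compound 4 (0.79 log units; beyond the scatter) and so recovers what the pyridin-4-yl side chain had lost. Against the 2-(4-chlorophenyl)ethenyl side chain the same replacement gives a 1.5-fold lower number from compound 2 to compound 4 (0.18 log units; within the scatter) and so the two all-carbon aromatic side chains cannot be told apart here, even though they differ in ring count and in the double bond outside aromatic rings, while compound 3 with its ring nitrogen remains the one with the higher number among these three. No measurement is at hand that would explain these differences.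

Still open, as far as these compounds go, is whether the nitrogen or the ethenyl link decides the number in compound 3, as both change together in the step to compound 4, and a pyridin-4-yl ring set directly on the saturated chain carbon would separate the two. From the compounds shown here alone, it is also open how this position responds to a saturated cyclohexyl ring, a longer alkyl chain, or an amine or carboxylic acid carried on the naphthalen-2-yl ring.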